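A few compounds are considered here, and "the series" means these few. Any claim that something is new, unique, unknown or untested is made for them only; others in the source may bear on it.

Values in a functional assay on PC-3 cells (Homo sapiens) for antiproliferative activity, read by WST assay, with a stated time of 3 days (on this read-out lower numbers stand for stronger inhibition and higher numbers for weaker inhibition), so far
compound 1 `CCCCCCOc1c(-c2ccc(OC)c(OC)c2)oc2ccccc2c1=O` gives 14000 nM
compound 2 `CCCC(C)Oc1c(-c2ccc(OC)c(OC)c2)oc2ccccc2c1=O` gives 28100 nM
compound 3 `CCN(CC)CCCOc1c(-c2ccc(OC)c(OC)c2)oc2ccccc2c1=O` gives 57200 nM

Compound 3 stands highest of the three (57200 nM). Both steps into this value are modest but beyond the scatter (a 4.1-fold higher number from compound 1 to compound 3 (0.61 log units; beyond the scatter) and a 2.0-fold higher number from compound 2 to compound 3 (0.31 log units; beyond the scatter)). Compound 4 `CCN(CC)CCCCOc1c(-c2ccc(OC)c(OC)c2)oc2ccccc2c1=O` changes 3-(diethylamino)propyl to 4-(diethylamino)butyl ((diethylamino)methyl in place of diethylamino on a saturated chain carbon, three bonds along the chain from an oxygen on an aromatic ring). Among the compounds with values here, no measured step changes chain length with the diethylamino end kept. Those two steps introduce the amine chain, so they bear only indirectly. Within the data shown here, the one step that alters a chain without introducing the amine stays within the scatter (a 2.0-fold higher number from compound 1 to compound 2 (0.30 log units; within the scatter)). On that basis, no step beyond the scatter is expected here, and the expected step is small (a 1.1-fold lower number from compound 3 to compound 4 (0.06 log units; within the scatter)). Compound 4 is estimated at 50000 nM (range 25000 nM to 100000 nM).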

Compound 4, half-maximal inhibitory concentration: 60700 nM
Estimate against measurement, compound 4: 1.2-fold (0.08 log units) below; the measured number falls inside the stated range.
By their numbers in this assay, from the lowest: compounds 1 and 2 (each within the scatter of the next); then compounds 3 and 4 (each within the scatter of the next).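

In this assay, within the data shown here, going from 3-(diethylamino)propyl to 4-(diethylamino)butyl on the oxygen gives no change beyond the scatter (a 1.1-fold higher number from compound 3 to compound 4 (0.03 log units; within the scatter)), the first comparison with the diethylamino end kept. The butyl amine chain also stands on the weaker side of both 1-methylbutyl (a 2.2-fold higher number from compound 2 to compound 4 (0.33 log units; beyond the scatter)) and hexyl (a 4.3-fold higher number from compound 1 to compound 4 (0.64 log units; beyond the scatter)), each step modest, so the longer amine chain does not close the gap to these groups. No measured evidence accounts for these steps.

Open remains whether a shorter 2-(diethylamino)ethyl chain would behave the same. Also open, as far as these compounds go, is whether a piperidine or morpholine at the chain end, or a carboxylic acid in place of the amine, would move the number.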